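Swapping the Amide Chain of Compound 3 for an Ester

This account rests on a few compounds, and the source may have more. Where it says the series, first, only, none or still open, it means among the compounds named here.

Compound 3 `COc1cc2[nH]c(-c3cccc(Oc4ccccc4)c3)c(C(=O)NCCCN3CCCC3)c(=O)c2cc1F` carries (3-(pyrrolidin-1-yl)propyl)amino on a carbonyl carbon. In an ADME assay on BJ cells (Homo sapiens) for cytotoxicity, read by luminescence, with a stated time of 72 h (on this read-out higher numbers stand for an effect only at larger amounts of compound and lower numbers for an effect already at smaller amounts), compound 3 gives > 21500 nM, which is a limit of the assay and not a number. Two relatives stand in the same place. In this assay, compound 1 `CCOC(=O)c1c(-c2cccc(Oc3ccccc3)c2)[nH]c2cc(OC)c(F)cc2c1=O` gives > 21500 nM, again a limit. Compound 2 `COc1cc2[nH]c(-c3cccc(Oc4ccccc4)c3)c(C(=O)NCCN3CCCC3)c(=O)c2cc1F` gives > 21500 nM, also a limit. Going by the values given here, the series so far therefore shows (the limit of > 21500 nM in this assay, at which 3 of the 3 values shown sit).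

Compound 4 `COCCOC(=O)c1c(-c2cccc(Oc3ccccc3)c2)[nH]c2cc(OC)c(F)cc2c1=O` has 2-methoxyethoxy in place of (3-(pyrrolidin-1-yl)propyl)amino on a carbonyl carbon. The nearest measured change is a step that the two limits leave unreadable from compound 1 to compound 3, which links ethoxy on that carbonyl carbon with the same (3-(pyrrolidin-1-yl)propyl)amino and so runs in the opposite sense. The other two measured changes are a step that the two limits leave unreadable from compound 1 to compound 2 and a step that the two limits leave unreadable from compound 2 to compound 3. None of the three yields a size. No step beyond the scatter is therefore expected in this assay, and no direction can be assigned. The expected outcome is a number no higher from compound 3 to compound 4 (the limit leaves the size open). For compound 4 the estimate is 21500 nM, with an expected range from 10000 nM to 45000 nM, and a report of only a limit is the most likely result.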

Compound 4, half-maximal effective concentration: > 21500 nM
Compound 4: no number, only a limit; the forecaster's own chance of this, stated with the estimate: 85%; the middle value lies on the limit itself.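

In this assay compound 4 gives > 21500 nM, which is a limit of the assay and not a number. No step linking compound 4 with compound 1, compound 2 or compound 3 can be read, because all four stand at the same limit: the limit of > 21500 nM in this assay, at which 4 of the 4 values shown sit.

The compounds shown leave open at what amount of compound any of the four would show an effect, and whether the changes on the carbonyl carbon alter that amount at all.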